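The source may report more compounds than this note shows. Statements on the series, on what has been measured and on what is new or still open speak of the compounds shown alone.

Working notes on the series, read in a functional assay on IMR-32 cells (Homo sapiens) for antiproliferative activity, with a stated time of 72 h; a higher number here means a weaker inhibitor, a lower number a stronger inhibitor. Compound 1 (`Cc1ccc(NC(=O)CCN(Cc2ccc(C(=O)NO)cc2)C(=O)c2cc(C)cc(C)c2)cc1`) gives 210 nM, compound 2 (`O=C(CCN(Cc1ccc(C(=O)NO)cc1)C(=O)c1ccccc1)NCc1ccccc1`) gives 2360 nM and compound 3 (`Cc1ccc(CNC(=O)CCN(Cc2ccc(C(=O)NO)cc2)C(=O)c2ccc(N(C)C)cc2)cc1`) gives 260 nM. Compound 3 lies within the scatter of compound 1, so the two cannot be told apart on these numbers. Compound 2 carries a higher number than compound 3, and that gap lies beyond the scatter.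

Among the compounds with values here, compound 4 (`CN(C)c1ccc(C(=O)N(CCC(=O)NCc2ccccc2)Cc2ccc(C(=O)NO)cc2)cc1`) has no measurement yet in this assay. Its difference from compound 3 is a single edit: hydrogen in place of methyl on an aromatic carbon. This is hydrogen in place of methyl on an aromatic carbon, para to a large group, which turns 4-methylbenzyl into benzyl. Within the data shown here, no pair of measured compounds isolates this change, so the data give no direct size for it. The reading for compound 2 at 2360 nM shows that numbers far above that of compound 3 do occur in this small set, so the expectation leans upward. The expected change is a modest rise in the number, a somewhat weaker inhibitor, with the estimated 1.7-fold higher number from compound 3 to compound 4 (0.24 log units; within the scatter) lying near the edge of the scatter. The estimate for compound 4 is 450 nM, with an expected range of 180 nM to 1100 nM.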

Compound 4, half-maximal inhibitory concentration: 840 nM
Compound 4: middle estimate off by 1.9-fold (0.27 log units), on the low side, and the stated range covers the measured number.
By their numbers in this assay, from the lowest: compounds 1 and 3 (each within the scatter of the next); then compound 4; then compound 2.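

In this assay, hydrogen in place of methyl on an aromatic carbon, para to a large group, now has a direct size with the dimethylamino group held constant (a 3.2-fold higher number from compound 3 to compound 4 (0.51 log units; beyond the scatter)), so the change from 4-methylbenzyl to benzyl is a modest step that lies beyond the scatter. The same compound also isolates a second place: with benzyl held constant, dimethylamino in place of hydrogen on an aromatic carbon gives a 2.8-fold lower number from compound 2 to compound 4 (0.45 log units; beyond the scatter), again modest and beyond the scatter, so each of these two single edits is separately detectable in this small set. Nothing on hand explains the size or direction of either step.

The compounds shown leave open whether a methoxy group or a chlorine atom on that same aromatic carbon would read closer to methyl or to hydrogen. They also leave open whether the methyl step keeps its size when hydrogen rather than dimethylamino stands on the other aromatic ring, as a single pair cannot show whether the step carries over to other members of the series.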